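This account rests on a few compounds, and the source may have more. Where it says the series, first, only, none or still open, it means among the compounds named here.

Measured so far:
compound 1, `Cc1ccc(OCC(=O)N(Cc2cccs2)c2ncco2)cc1`: 0.3 nM
compound 2, `CCN(Cc1cccs1)C(=O)c1cc2cc(C)ccc2[nH]1`: 2010 nM
compound 3, `CCN(Cc1ccncc1)C(=O)COc1ccc(C)cc1`: "not active" (no number reported)

In an assay on HEK293 cells for agonist activity at transient receptor potential cation channel subfamily M member 8 (Homo sapiens), read by fluorescence and calcium flux, with a stated time of 15 min (a higher number here means that more compound is needed for the effect, a lower number that less compound is needed), compound 1 gives 0.3 nM, the lowest of the two numbers reported. Its nearest neighbour by value is compound 2, which in this assay gives 2010 nM, a gap far beyond the scatter of repeated measurements. Compound 3 in this assay is reported as "not active" (no number reported), so no number exists for it. None of these three compounds differs from another in a single place, so no single-change step can be read from the measured values.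

The compound not yet measured is compound 4, `Cc1ccc(OCC(=O)N(C)Cc2cccs2)cc1`. It differs from compound 1 as follows: methyl in place of 1,3-oxazol-2-yl on an amide-type nitrogen. The change sits on an amide-type nitrogen whose other neighbours are a carbonyl carbon and a saturated chain carbon.

For the measured compounds named here, with no comparable step measured, the size of the move from compound 1 to compound 4 in this assay is uncertain. Since compound 1 stands at 0.3 nM, a step toward a higher number, beyond the scatter, is expected for compound 4. The estimate for compound 4 is 100 nM, within 5 nM to 3000 nM, corresponding to an expected step of a 330-fold higher number from compound 1 to compound 4 (2.52 log units; beyond the scatter).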

Compound 4, half-maximal effective concentration: 400 nM
For compound 4 the middle estimate is 4.0-fold (0.60 log units) below the measured one; the measured number falls inside the stated range.
By their numbers in this assay, from the lowest: compound 1; then compound 4; then compound 2.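

For the compounds shown here, replacing the 1,3-oxazol-2-yl on the amide-type nitrogen with methyl gives, in this assay, a 1300-fold higher number from compound 1 to compound 4 (3.12 log units; beyond the scatter) and is the first single-place change that can be read in this set. The step shows that the group on this nitrogen, whose other neighbours are a carbonyl carbon and a saturated chain carbon, has a large bearing on the number, while compound 4 still gives a measured value of 400 nM in this assay with the five-membered aromatic ring gone. Nothing offered here accounts for the size of this step.

This one step swaps a ring with two hetero atoms for a single carbon, so it cannot separate the loss of the ring itself from the loss of its hetero atoms, and on the core of compound 1 the compounds shown carry only these two groups at this nitrogen. As far as these compounds go, whether a phenyl ring, a 1,3-thiazol-2-yl ring or a longer chain such as propyl at this place would give a number close to that of compound 1 or to that of compound 4 remains open.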